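From 3-methylphenyl to 4-bromophenyl on a shared core

The compounds below may be only part of what the source reports. "The series", "measured", "known", "first", "only" and "open" are said of these compounds alone.

In a functional assay on NCI-H1975 cells (Homo sapiens) for cytotoxicity, read by MTT assay, with a stated time of 72 h (a higher number here means a weaker inhibitor, a lower number a stronger inhibitor), compound 1 `CC(C)n1c(Nc2ccccc2)nc2cnc(Nc3ccc(N4CCN(C)CC4)cc3)nc21` gives 960 nM, compound 2 `CN1CCN(c2ccc(Nc3ncc4nc(Nc5cccc([N+](=O)[O-])c5)n(C5CCCC5)c4n3)cc2)CC1` gives 980 nM and compound 3 `Cc1cccc(Nc2nc3cnc(Nc4ccc(N5CCN(C)CC5)cc4)nc3n2C2CCCC2)c1` gives 560 nM. The gaps from compound 3 to the other two lie within the scatter, so the three stand level. Compound 4 `CN1CCN(c2ccc(Nc3ncc4nc(Nc5ccc(Br)cc5)n(C5CCCC5)c4n3)cc2)CC1` has 4-bromophenyl in place of 3-methylphenyl on a nitrogen on an aromatic ring. Among the compounds with values here, the one measured step on this aryl group is a 1.8-fold lower number from compound 2 to compound 3 (0.24 log units; within the scatter), with methyl in place of nitro on an aromatic carbon. Within the data shown here, no measured compound carries bromine, so no change beyond the scatter is expected, in either direction. The expected step is a 1.3-fold higher number from compound 3 to compound 4 (0.10 log units; within the scatter). For compound 4 the estimated value is 700 nM, with an expected range from 280 nM to 1700 nM.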

Compound 4, half-maximal inhibitory concentration: 2090 nM
The estimate for compound 4 lay 3.0-fold (0.48 log units) below the measured number; measured number outside the range, above it.
By their numbers in this assay, from the lowest: compounds 3, 1 and 2 (each within the scatter of the next); then compound 4.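

In this assay the aryl group on this nitrogen now shows that it can matter: 4-bromophenyl brings a 3.7-fold higher number from compound 3 to compound 4 (0.57 log units; beyond the scatter) and also a 2.1-fold higher number from compound 2 to compound 4 (0.33 log units; beyond the scatter) and both steps lie beyond the scatter, though both are modest. The earlier step between the 3-nitrophenyl and 3-methylphenyl compounds stayed within the scatter. No available evidence explains this weakening. The change swaps the group and its ring position together, so the shown compounds cannot separate bromine from position. On these data alone, how 3-bromophenyl, or a phenyl ring carrying an amine or a carboxylic acid, would behave here remains open.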